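Flat growth inhibition so far; a dichlorophenyl change next

The source may report more compounds than this note shows. Statements on the series, on what has been measured and on what is new or still open speak of the compounds shown alone.

Measured in a functional assay on MIA PaCa-2 cells (Homo sapiens) for inhibition, read by MTT assay, with a stated time of 48 h, tested at 10 uM; on this read-out higher numbers stand for more inhibition of growth at the one concentration tested and lower numbers for less inhibition of growth:
- compound 1 `Cc1cc(=O)c2c(O)cc(OCc3ccccc3)c([C@H]3CCN(C)C[C@H]3O)c2o1`: 14%
- compound 2 `Cc1cc(=O)c2c(O)cc(OC/C=C/c3ccccc3)c([C@H]3CCN(C)C[C@H]3O)c2o1`: 11%
- compound 3 `Cc1oc2c([C@H]3CCN(C)C[C@H]3O)c(O)cc(O)c2c(=O)c1C(O)c1ccccc1Br`: 10%

Compound 3 at 10% sits within the scatter of the other two measured compounds, so no order can be drawn among the three. The next structure is compound 4 `Cc1oc2c([C@H]3CCN(C)C[C@H]3O)c(O)cc(O)c2c(=O)c1C(O)c1cccc(Cl)c1Cl`, and the difference is 2,3-dichlorophenyl in place of 2-bromophenyl on a saturated chain carbon bound to an aromatic carbon and an oxygen on a saturated carbon. In words, 2,3-dichlorophenyl stands in place of 2-bromophenyl on a saturated chain carbon bound to an aromatic carbon and an oxygen on a saturated carbon.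

For the measured compounds named here, only one measured step is available, a number 3 percentage points lower from compound 1 to compound 2 (within the scatter). It lies within the scatter and concerns a different place, a saturated chain carbon bound to an oxygen on an aromatic ring, so it bears on this change only indirectly. Going by the values given here, no measured step covers a change of this aryl group. All three values in this assay are close together, which gives no ground to expect a shift in either direction. The estimated step is a number 2 percentage points higher from compound 3 to compound 4 (within the scatter), which is expected to stay within the scatter. For compound 4 the estimated value is 12%, with an expected range of 4% to 24%.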

Compound 4, percent growth inhibition at one concentration: 2%
Beside the measured number, compound 4's estimate is 10 percentage points above it; measured number outside the range, below it.
By their numbers in this assay, from the lowest: compounds 4, 3, 2 and 1 (each within the scatter of the next, the first and the last beyond it).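

For the compounds shown here, this is the first measured step at the aryl group on a saturated chain carbon bound to an aromatic carbon and an oxygen on a saturated carbon: in this assay, 2,3-dichlorophenyl in place of 2-bromophenyl gives a number 8 percentage points lower from compound 3 to compound 4 (within the scatter) and so does not separate the pair. Exchanging the single bromine for two chlorines on this phenyl ring leaves growth inhibition low at the one concentration tested, with compound 3 at 10% and compound 4 at 2% not distinguishable from each other. No measurement at hand offers an explanation for this result.

As far as these compounds go, with only these two aryl groups at this place, it stays open whether an unsubstituted phenyl, a methoxyphenyl or a pyridyl ring would give a number beyond the scatter. Equally open, from the compounds shown here alone, is whether an amine or a carboxylic acid on this saturated chain carbon, in place of the hydroxy group, would raise inhibition of growth in this assay above the low numbers seen for the shared core so far.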